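The source may hold more compounds than are shown below. What is called first, only, known or untested is meant among the compounds shown, and "the series" means these compounds.

In a functional assay on HL-60 cells (Homo sapiens) for cytotoxicity, read by WST assay, with a stated time of 48 h (on this read-out lower numbers stand for an effect already at smaller amounts and higher numbers for an effect only at larger amounts of compound), compound 1 (`O=C1OC[C@H](Cc2ccccc2)[C@H]1Cc1ccc(C(F)(F)F)cc1`) gives 22000 nM and compound 2 (`O=C1OC[C@H](Cc2ccccc2)[C@H]1Cc1ccc(F)c(F)c1`) gives 50000 nM while compound 3 (`COc1ccccc1C[C@H]1COC(=O)[C@@H]1Cc1ccc(Cl)c(Cl)c1`) gives 14000 nM on the same read-out. Compound 3 thus lies within the scatter of compound 1, and compound 2 stands clearly higher than compound 3 on these numbers. Among the compounds with values here, these three compounds share a core but differ in more than one place, so no measured pair isolates a single change.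

Compound 4 (`O=C1OC[C@H](Cc2ccccc2F)[C@H]1Cc1ccc(Cl)c(Cl)c1`) has not yet been measured. It differs from compound 3 by fluoro in place of methoxy on an aromatic carbon, ortho to a large group (fluoro in place of methoxy on an aromatic carbon), which turns 2-methoxyphenyl into 2-fluorophenyl. Within the data shown here, the data hold no direct precedent for this swap, so the expectation rests on compound 3 at 14000 nM as the closest measured structure. Only a small rise in the number is expected, with no shift beyond the scatter. The estimated change is a 1.3-fold higher number from compound 3 to compound 4 (0.11 log units; within the scatter) in this assay and remains uncertain in both size and direction. In this assay the estimated value for compound 4 is 18000 nM within an expected range from 8000 nM to 40000 nM for repeated measurements.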

Compound 4, half-maximal effective concentration: 28000 nM
Beside the measured number, compound 4's estimate is 1.6-fold (0.19 log units) below it; the range from low to high includes it.
By their numbers in this assay, from the lowest: compounds 3, 1, 4 and 2 (each within the scatter of the next, the first and the last beyond it).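

In this assay, within the data shown here, replacing methoxy with fluoro on an aromatic carbon ortho to a large group gives a 2.0-fold higher number from compound 3 to compound 4 (0.30 log units; within the scatter) and is the first measured step here that isolates a single change. Among these compounds, at this position of the 2-methoxyphenyl group, the swap to 2-fluorophenyl therefore leaves the read-out within the usual scatter, something the earlier compounds, which differ in more than one place, could not show. No measured information bears on what lies behind this result.

The compounds shown leave open how this position responds to other kinds of groups, such as an amine, a carboxylic acid or a longer chain like ethoxy, as the only comparison here is between methoxy and fluoro. Among the compounds shown here, they also leave open whether the same swap would read alike alongside the other substituted aromatic groups in compound 1 and compound 2, as this single pair offers the only view of the change and its outcome on that part of the shared core remains unknown.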